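This account rests on a few compounds, and the source may have more. Where it says the series, first, only, none or still open, it means among the compounds named here.

Results so far in a functional assay on PC-3 cells (Homo sapiens) for inhibition, read by sulforhodamine B assay, with a stated time of 48 h, tested at 50 uM; a higher number here means more inhibition of growth at the concentration tested, a lower number less inhibition of growth
Compound 1 `COc1cc(/C=C/C(=O)/C=C/c2cccc3ccccc23)ccc1OCc1cn(CCOc2cc(=O)oc3ccccc23)nn1` gives 20%
Compound 2 `COc1cc(/C=C/C(=O)/C=C/c2cccc3ccccc23)ccc1OCc1cn(CCCOc2cc(=O)oc3ccccc23)nn1` gives 8%
Compound 3 `COc1ccc(/C=C/C(=O)/C=C/c2ccc(OCc3cn(CCCCOc4cc(=O)oc5ccccc45)nn3)c(OC)c2)cc1OC` is reported as "not active" (no number reported)

Compound 1 holds the higher of the two numbers, and its gap to compound 2 lies beyond the usual scatter. Compound 3 gives no number to compare. Even compound 1 shows only modest inhibition of growth in this assay at the single concentration tested.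

Compound 4 `COc1cc(/C=C/C(=O)/C=C/c2cccs2)ccc1OCc1cn(CCOc2cc(=O)oc3ccccc23)nn1` is still to be measured. It keeps the core of compound 1 but carries thiophen-2-yl in place of naphthalen-1-yl on a double-bonded chain carbon bound to a double-bonded chain carbon.

For the measured compounds named here, no measured pair shows this exchange, so the data give no direct size for the step. Going by the values given here, the only guide is the range of the readings, with compound 1 at 20% as the top number and compound 2 lower at 8%. A small downward move therefore seems more likely than a rise, and a reading without a number, like that of compound 3 "not active" (no number reported), remains possible. The expected change is a number 8 percentage points lower from compound 1 to compound 4 (within the scatter), about the size of the usual scatter. For compound 4 the estimated value is 12%, with an expected range from 0% to 30%.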

Compound 4, percent growth inhibition at one concentration: 12%
For compound 4 middle estimate and measured number coincide at the digits printed; the range from low to high includes it.
By their numbers in this assay, from the lowest: compounds 2, 4 and 1 (each within the scatter of the next, the first and the last beyond it).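

In this assay, placing thiophen-2-yl in place of naphthalen-1-yl on a double-bonded chain carbon bound to a double-bonded chain carbon gives a number 8 percentage points lower from compound 1 to compound 4 (within the scatter), the first step among these compounds that can be read at this position. The exchange is a large one in structure, since 10 heavy atoms in two six-membered aromatic rings of carbon only give way to 5 heavy atoms in one five-membered aromatic ring with 1 hetero atom, yet the reading does not move beyond the scatter, so this single step gives no sign that the choice between these two groups matters for this read-out. No measurement here explains this outcome.

The compounds shown leave open whether any group at this place could move the reading beyond the scatter, such as a phenyl ring carrying an amine or a carboxylic acid, or a pyridine ring. They also leave open whether thiophen-2-yl would give a similar reading on the longer chain of compound 2.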